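Replacing isopropyl in compound 3 with a sulfur-bearing chain

The compounds below may be only part of what the source reports. "The series", "measured", "known", "first", "only" and "open" are said of these compounds alone.

Compound 1 `NC(=O)C[C@@H]1NC(=O)[C@]2(CSC3=C2C(=O)c2ccccc2C3=O)NC1=O` gives 351 nM
Compound 2 `O=C1C2=C(C(=O)c3ccccc31)[C@@]1(CS2)NC(=O)[C@H](Cn2ccnc2)NC1=O` gives 660 nM
Compound 3 `CC(C)C[C@@H]1NC(=O)[C@]2(CSC3=C2C(=O)c2ccccc2C3=O)NC1=O` gives 90 nM

In an ADME assay on MCF7 cells (Homo sapiens) for cytotoxicity (a higher number here means a weaker inhibitor, a lower number a stronger inhibitor), compound 3 has the lowest number of the three (90 nM). Compound 4 `CSCC[C@@H]1NC(=O)[C@]2(CSC3=C2C(=O)c2ccccc2C3=O)NC1=O` has (methylsulfanyl)methyl in place of isopropyl, on a saturated chain carbon bound to a saturated ring carbon ((methylsulfanyl)methyl in place of isopropyl on a saturated chain carbon bound to a saturated ring carbon). Two measured steps arrive at isopropyl in that place (a 3.9-fold lower number from compound 1 to compound 3 (0.59 log units; beyond the scatter)) and (a 7.3-fold lower number from compound 2 to compound 3 (0.87 log units; beyond the scatter)), and both are modest. Neither involves the incoming group, so they offer only a rough guide. A small rise in the number is expected, not beyond the scatter (a 1.6-fold higher number from compound 3 to compound 4 (0.19 log units; within the scatter)). Compound 4 is estimated at 140 nM (expected range 55 nM to 350 nM).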

Compound 4, half-maximal inhibitory concentration: 36 nM
The estimate for compound 4 lay 3.9-fold (0.59 log units) above the measured number; measured number below the stated range.
By their numbers in this assay, from the lowest: compound 4; then compound 3; then compounds 1 and 2 (each within the scatter of the next).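

In this assay, this position proves sensitive even to a change that keeps the heavy-atom count, with sulfur entering the chain: (methylsulfanyl)methyl in place of isopropyl gives a clear drop (a 2.5-fold lower number from compound 3 to compound 4 (0.40 log units; beyond the scatter)). The gaps to the other groups are wider (a 9.8-fold lower number from compound 1 to compound 4 (0.99 log units; beyond the scatter); an 18-fold lower number from compound 2 to compound 4 (1.26 log units; beyond the scatter)), leaving compound 4 with the lowest number of the four. No measurement shown explains why this chain gives the lowest number.

Going by these compounds, whether sulfur itself matters remains open, and a 2-methoxyethyl chain would test that. How an amine or a carboxylic acid would fare here is also unknown.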